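This account rests on a few compounds, and the source may have more. Where it says the series, first, only, none or still open, it means among the compounds named here.

Compound 1 `O=S1(=O)C=Cc2cccc(Nc3ccc(C(F)(F)F)cc3)c21` gives 1200 nM
Compound 2 `Cc1cc(C)cc(Nc2cccc3c2S(=O)(=O)C=C3)c1` gives 3120 nM

In a functional assay on MDA-MB-231 cells (Homo sapiens) for antiproliferative activity, read by MTT assay, with a stated time of 72 h (on this read-out lower numbers stand for stronger inhibition and higher numbers for weaker inhibition), compound 1 gives the lower of the two numbers, and its 1200 nM stands apart from compound 2 by more than the usual scatter. Compound 3 `Cc1ccc(Nc2cccc3c2S(=O)(=O)C=C3)cc1` shares the core of compound 1 and has methyl in place of trifluoromethyl on an aromatic carbon, para to a large group (methyl in place of trifluoromethyl on an aromatic carbon). Among the compounds with values here, no measured pair shows this change alone. Compound 2 also lacks trifluoromethyl and carries methyl, and its 3120 nM is the higher number. A modest rise in this assay is therefore expected for compound 3, of a size near the edge of the scatter and possibly within it. The expected change is a 2.0-fold higher number from compound 1 to compound 3 (0.30 log units; within the scatter) and would mean somewhat weaker inhibition. For compound 3 the estimated value is 2400 nM with an expected range from 1000 nM to 5500 nM.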

Compound 3, half-maximal inhibitory concentration: 1560 nM
Estimate against measurement, compound 3: 1.5-fold (0.19 log units) above; low and high end bracket the measured number.
By their numbers in this assay, from the lowest: compounds 1, 3 and 2 (each within the scatter of the next, the first and the last beyond it).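

In this assay, the swap at this position, methyl in place of trifluoromethyl on an aromatic carbon, para to a large group, comes to a 1.3-fold higher number from compound 1 to compound 3 (0.11 log units; within the scatter), the first time this change has been seen alone. On the shared core, the two groups therefore cannot be told apart at this position by this read-out, so the three fluorine atoms are not needed here for a number of this size. Nothing measured in this account bears on why the two groups read alike.

Still open, on these data alone, is whether a different kind of group at this position, such as an amine, a carboxylic acid or a methoxy group, would move the number beyond the scatter. As far as these compounds go, it is also open whether the same swap would read alike on other cell lines.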